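A few compounds are considered here, and "the series" means these few. Any claim that something is new, unique, unknown or untested is made for them only; others in the source may bear on it.

Measured compounds in a functional assay on DLD-1 cells (Homo sapiens) for cytotoxicity, read by MTT assay, with a stated time of 96 h; a lower number here means a stronger inhibitor, a higher number a weaker inhibitor:

compound 1, `CCOCc1cc(O)c(O)c(Br)c1`, gives 35100 nM
compound 2, `CCOCc1cc(O)c(O)c(Br)c1Br`, gives 13500 nM
compound 3, `CCCOCc1cc(O)c(O)c(Br)c1`, gives 26300 nM

Compound 2 differs from compound 1 by bromo in place of hydrogen on an aromatic carbon. That change gave a 2.6-fold lower number from compound 1 to compound 2 (0.41 log units; beyond the scatter).

Compound 3 and compound 1 share a core, and the two cores differ by methyl in place of hydrogen on a saturated chain carbon, two bonds along the chain from an oxygen on a saturated carbon. This change gave a 1.3-fold lower number from compound 1 to compound 3 (0.13 log units; within the scatter), so compound 3 and compound 1 are read as equivalent within the usual scatter.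

Compound 4, `CCCOCc1cc(O)c(O)c(Br)c1Br`, has not yet been measured in this assay. It differs from compound 3 by bromo in place of hydrogen on an aromatic carbon. The surroundings of the changed position are not identical to those in the earlier pair: here the new bromo group is ortho to a propoxymethyl group, whereas in compound 2 it is ortho to an ethoxymethyl group. The change is therefore the same kind of change as that from compound 1 to compound 2, not the same change.

Among the measured compounds shown here, the step from compound 3 to compound 4 is expected to be close to the one from compound 1 to compound 2, resting on a 2.6-fold lower number from compound 1 to compound 2 (0.41 log units; beyond the scatter) and on the small size of the core difference seen in a 1.3-fold lower number from compound 1 to compound 3 (0.13 log units; within the scatter). The expected step is a 2.6-fold lower number from compound 3 to compound 4 (0.42 log units; beyond the scatter). For the measured compounds named here, only one prior example of this change is available, so the expectation carries a wide range. Compound 4 is estimated to give 10000 nM, with a range from 5000 nM to 20000 nM.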

Compound 4, half-maximal inhibitory concentration: 12400 nM
Estimate against measurement, compound 4: 1.2-fold (0.09 log units) below; the measured number falls inside the stated range.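

In this assay, bromo in place of hydrogen on the aromatic carbon gave a 2.1-fold lower number from compound 3 to compound 4 (0.33 log units; beyond the scatter), so the step carried over from the ethoxymethyl core to the propoxymethyl core: the same change on two cores in this assay, a 2.6-fold lower number (0.41 log units; beyond the scatter) from compound 1 to compound 2 and a 2.1-fold lower number (0.33 log units; beyond the scatter) from compound 3 to compound 4, 1.2-fold (0.09 log units) apart, within the scatter of two such steps. Methyl in place of hydrogen on the saturated chain carbon gave a 1.1-fold lower number from compound 2 to compound 4 (0.04 log units; within the scatter), so the chain change again reads as no difference, with or without the second bromo group: the same change on two cores in this assay, a 1.3-fold lower number (0.13 log units; within the scatter) from compound 1 to compound 3 and a 1.1-fold lower number (0.04 log units; within the scatter) from compound 2 to compound 4, 1.2-fold (0.09 log units) apart, within the scatter of two such steps. The two changes therefore behave as independent across these four compounds, but that rests on a single pair of cores for each change and shows nothing about cores further removed or about any other cell line or read-out.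

The compounds shown leave open whether the bromo step holds with a longer chain, such as a butoxymethyl or benzyloxymethyl group, or with an amine in place of the ether. They also leave open whether chloro or iodo in place of bromo gives a similar step, and what happens when a methoxy group replaces either hydroxy group.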